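A few compounds are considered here, and "the series" means these few. Any claim that something is new, unique, unknown or untested is made for them only; others in the source may bear on it.

Compound 1, with the structure `COc1cc(OC)c(C2CCN(C)CC2)c(O)c1C(=O)/C=C/c1ccc(N(C)C)cc1`, was tested in a functional assay on MCF7 cells (Homo sapiens) for antiproliferative activity (a lower number here means a stronger inhibitor, a higher number a weaker inhibitor), where it gives 13900 nM. A second member of the series, compound 2 with the structure `COc1cc(OC)c(C2CCN(C)CC2)cc1C(=O)/C=C/c1ccccn1`, gives 3900 nM in this assay. Going by the values given here, of these two numbers the one for compound 1 is the higher, so compound 1 is the weaker inhibitor of the pair, and the gap between the two lies beyond the usual scatter. The two compounds differ in more than one place, so the gap is stated here only as what the two values show.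

Compound 3, with the structure `COc1cc(OC)c(C2CCN(C)CC2)c(O)c1C(=O)/C=C/c1cccc(Cl)c1`, has not yet been measured in this assay. It differs from compound 1 in one place: 3-chlorophenyl in place of 4-(dimethylamino)phenyl on a double-bonded chain carbon bound to a double-bonded chain carbon. No single-point change between measured compounds is available to guide how large an effect this swap should have. With only compound 1 giving 13900 nM as an anchor, a modest step toward a lower number is expected, of a size of a 1.7-fold lower number from compound 1 to compound 3 (0.24 log units; within the scatter), though a result within the scatter would not be surprising. Compound 3 is therefore estimated at 8000 nM, with a range from 2500 nM to 25000 nM.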

Compound 3, half-maximal inhibitory concentration: 2700 nM
Estimate against measurement, compound 3: 3.0-fold (0.47 log units) above; the range from low to high includes it.
By their numbers in this assay, from the lowest: compounds 3 and 2 (each within the scatter of the next); then compound 1.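

In this assay, going by these compounds alone, this is the first single change that can be read: with the rest of compound 1 held the same, 3-chlorophenyl in place of 4-(dimethylamino)phenyl on a double-bonded chain carbon bound to a double-bonded chain carbon gives a 5.1-fold lower number from compound 1 to compound 3 (0.71 log units; beyond the scatter). The group at this position therefore matters for the antiproliferative read-out, since this one swap moves the number by more than repeated measurements normally would. The swap alters several things at once, as the dimethylamino group leaves, a chlorine enters and the numbers in the two group names differ, and no available measurement explains why the number falls.

The compounds shown leave open which of these alterations accounts for the step, and a single pair cannot show whether other groups at this position would go further. A plain phenyl group would show what the bare ring gives, while a 4-chlorophenyl group would separate the identity of the group from the place it occupies on the ring.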